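Whole-animal antagonist read-out of a butyne-linked series

This account rests on a few compounds, and the source may have more. Where it says the series, first, only, none or still open, it means among the compounds named here.

Measured so far:
compound 1 `COC(=O)N(C)CC#CCn1ccnc1`; in a functional assay on the whole organism for antagonist activity, with Mus musculus as the target (on this read-out higher numbers stand for an effect only at larger amounts of compound and lower numbers for an effect already at smaller amounts), compound 1 gives only a limit, > 100 mg/kg.
compound 2 `COC(=O)N(C)CC#CCN(C)C`; in this assay compound 2 gives only a limit, > 30 mg/kg.
compound 3 `CN1CCN(CC#CCn2ccnc2)C1=O`; in this assay compound 3 gives only a limit, > 100 mg/kg.

Within the data shown here, no compound has yet given a number: two values sit at the limit of > 100 mg/kg in this assay, at which 2 of the 3 values shown sit, and one at the limit of > 30 mg/kg in this assay, at which 1 of the 3 values shown sits. Going by these compounds, the change dimethylamino in place of 1H-imidazol-1-yl on a saturated chain carbon bound to a triple-bonded carbon yields a step that the two limits leave unreadable from compound 1 to compound 2, so its size is unknown. Compound 3 is built on a different core from compound 1; the difference between the two cores is not broken down here. Compound 4 `CN(C)CC#CCN1CCN(C)C1=O` carries the same change on the core of compound 3: dimethylamino in place of 1H-imidazol-1-yl on a saturated chain carbon bound to a triple-bonded carbon. The step from compound 3 to compound 4 is expected to be a step that the limit leaves unreadable from compound 3 to compound 4, resting on the unreadable a step that the two limits leave unreadable from compound 1 to compound 2 and on the limits shown by all three measured compounds. Compound 4 is therefore estimated at 150 mg/kg, with a range from 40 mg/kg to 600 mg/kg, and most likely again only a limit.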

Compound 4, dose for half-maximal effect: > 10 mg/kg
Compound 4: only a limit was reported; the forecaster's own chance of this, stated with the estimate: 80%; the middle value lies beyond the limit too.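

Compound 3 and compound 4 both give only limits in this assay, and no step can be read from compound 3 to compound 4. The compounds shown leave open whether dimethylamino in place of 1H-imidazol-1-yl alters the effective dose on either core: none gives a number.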